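Terminal chain polar group swap in a cytotoxicity series

This account rests on a few compounds, and the source may have more. Where it says the series, first, only, none or still open, it means among the compounds named here.

Measured so far in a functional assay on U-87MG ATCC cells (Homo sapiens) for cytotoxicity, read by MTT assay, with a stated time of 24 h; a higher number here means a weaker inhibitor, a lower number a stronger inhibitor:
Compound 1, `Cn1cc(NC(=O)CCCCCCCCCCS)c(-c2ccccn2)n1`, gives only a limit, > 150000 nM.
Compound 2, `Cn1cc(NC(=O)CCCCCCCCCCCN)c(-c2ccccn2)n1`, gives 90000 nM.

Among the compounds with values here, compound 2 holds the only number in this assay; the other value shown is a limit, (the limit of > 150000 nM in this assay, at which 1 of the 2 values shown sits). The step of an at least 1.6-fold lower number from compound 1 to compound 2 (0.22 log units; that floor lies within the scatter) covers aminomethyl in place of sulfanyl at the same chain position, and its floor lies within the scatter, so it gives no firm direction. Compound 3, `Cn1cc(NC(=O)CCCCCCCCCCO)c(-c2ccccn2)n1`, differs from compound 2 by hydroxy in place of aminomethyl on a saturated chain carbon, ten or more bonds along the chain from a carbonyl carbon. Within the data shown here, no measured step covers an aminomethyl to hydroxy exchange, so the expectation rests on compound 2 alone, with the limit of compound 1 as the only other point of reference. A step of roughly a 1.3-fold higher number from compound 2 to compound 3 (0.12 log units; within the scatter) is expected, not clearly beyond the scatter, with a real chance that this assay again reports only a limit. Compound 3 is estimated at 120000 nM, within 50000 nM to 300000 nM.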

Compound 3, half-maximal inhibitory concentration: > 150000 nM
Compound 3: only a limit was reported (the forecaster's own chance of this, stated with the estimate: 40%); middle value at least 1.2-fold (0.09 log units) from the limit.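

Hydroxy in place of aminomethyl on a saturated chain carbon gives an at least 1.6-fold higher number from compound 2 to compound 3 (0.22 log units; that floor lies within the scatter) in this assay, so this exchange sets no firm direction at this position. The step from compound 1 to compound 3 cannot be read, as both values are limits. Compound 3 now joins compound 1 in reporting only a limit, leaving compound 2 as the sole compound with a number: the limit of > 150000 nM in this assay, at which 2 of the 3 values shown sit.

Going by these compounds, whether aminomethyl truly differs from hydroxy or sulfanyl at this position stays open, as only limits stand against the value of compound 2. On these data alone, how a carboxylic acid or a dimethylamino group at this position, or a longer chain, would read in this assay also stays open.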